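Replacing the bromoalkyl chain on the aromatic ether oxygen

The source may hold more compounds than are shown below. What is called first, only, known or untested is meant among the compounds shown, and "the series" means these compounds.

In a functional assay on U-937 cells (Homo sapiens) for cytotoxicity, read by MTT assay, with a stated time of 24 h (on this read-out higher numbers stand for weaker inhibition and lower numbers for stronger inhibition), compound 1 `BrCCCOc1c(Br)cc(Br)cc1Oc1ccc(Br)cc1Br` gives 30.3 ug/mL, and compound 2 `BrCCCCCOc1c(Br)cc(Br)cc1Oc1ccc(Br)cc1Br` gives 29.5 ug/mL. These two values lie within the scatter of each other, so compound 2 stands level with compound 1. Within the data shown here, the only measured step is a 1.0-fold lower number from compound 1 to compound 2 (0.01 log units; within the scatter), and it concerns chain length alone.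

Compound 3 `CC(C)(C)C(=O)C(C#N)Oc1c(Br)cc(Br)cc1Oc1ccc(Br)cc1Br` carries a different kind of change: cyano((tert-butyl)carbonyl)methyl in place of 5-bromopentyl on an oxygen on an aromatic ring. In it, cyano((tert-butyl)carbonyl)methyl takes the place of 5-bromopentyl on an oxygen on an aromatic ring. Among the measured compounds shown here, no measured step covers a replacement of this kind, so the step between compound 1 and compound 2 offers only weak guidance and gives no direction. The data therefore support no shift beyond the scatter, though the uncertainty is wide. The expected step is a 1.3-fold lower number from compound 2 to compound 3 (0.13 log units; within the scatter). For compound 3 the estimated value is 22 ug/mL, with an expected range of 7 ug/mL to 60 ug/mL.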

Compound 3, half-maximal inhibitory concentration: 32.5 ug/mL
Estimate against measurement, compound 3: 1.5-fold (0.17 log units) below; measured number inside the range.
By their numbers in this assay, from the lowest: compounds 2, 1 and 3 (each within the scatter of the next).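

In this assay cyano((tert-butyl)carbonyl)methyl in place of 5-bromopentyl leaves the number within the scatter (a 1.1-fold higher number from compound 2 to compound 3 (0.04 log units; within the scatter)), and the same holds in place of 3-bromopropyl (a 1.1-fold higher number from compound 1 to compound 3 (0.03 log units; within the scatter)). On this oxygen on an aromatic ring, then, a group without bromine, carrying a carbonyl and a nitrile, stands level with both bromoalkyl chains, so in these three compounds a chain-end bromine is not required for this read-out. No measurement shown speaks to the mechanism behind this read-out.

Going by these compounds, whether an amine, a carboxylic acid or a chain longer than 5-bromopentyl on this oxygen would move the number beyond the scatter remains open. On these data alone, the contribution of the bromine atoms on the shared core also stays open.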